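Trifluoromethyl to difluoromethyl: working notes on compound 2

This account rests on a few compounds, and the source may have more. Where it says the series, first, only, none or still open, it means among the compounds named here.

Measured so far in an in vivo ADME assay on the whole organism (strain Wistar) for pharmacokinetics, with Rattus norvegicus as the target, at a dose of 100 mg/kg by the oral route; on this read-out lower numbers stand for lower exposure and higher numbers for higher exposure at the dose given:
- compound 1 `CCC(=O)NS(=O)(=O)c1ccc(-n2nc(C(F)F)cc2-c2ccc(Br)cc2)cc1CO`: 55100 nM
- compound 2 `CCC(=O)NS(=O)(=O)c1ccc(-n2nc(C(F)(F)F)cc2-c2ccc(OC)c(C)c2)cc1CO`: 18700 nM

Compound 2, at 18700 nM, is the lower of the two numbers. Compound 1 stands higher, and the gap between them lies beyond the scatter. The two compounds differ in more than one place, so their gap cannot be assigned to any single change.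

Compound 3 `CCC(=O)NS(=O)(=O)c1ccc(-n2nc(C(F)F)cc2-c2ccc(OC)c(C)c2)cc1CO` is not yet measured. It differs from compound 2 in one place: hydrogen in place of fluoro on a saturated chain carbon bound to an aromatic carbon and two fluorine atoms. This is hydrogen in place of fluoro on a saturated chain carbon bound to an aromatic carbon and two fluorine atoms, that is, trifluoromethyl to difluoromethyl.

Within the data shown here, no measured pair isolates this change. Among the measured compounds shown here, the only guide is compound 1 at 55100 nM, which also carries difluoromethyl but differs elsewhere as well, and this gives only a weak lean upward. A small rise, probably not beyond the scatter, is expected in this assay. The expected size is a 1.4-fold higher number from compound 2 to compound 3 (0.16 log units; within the scatter). For compound 3 the estimate is 27000 nM, with an expected range of 11000 nM to 65000 nM.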

Compound 3, maximal plasma concentration: 15700 nM
Estimate against measurement, compound 3: 1.7-fold (0.24 log units) above; the range from low to high includes it.
By their numbers in this assay, from the lowest: compounds 3 and 2 (each within the scatter of the next); then compound 1.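

In this assay the trifluoromethyl to difluoromethyl change now has a pair of its own, and a 1.2-fold lower number from compound 2 to compound 3 (0.08 log units; within the scatter) stays within the scatter, so with 4-methoxy-3-methylphenyl in the molecule, hydrogen in place of this one fluoro leaves no readable difference in the maximal plasma concentration. With difluoromethyl held constant, 4-methoxy-3-methylphenyl in place of 4-bromophenyl on an aromatic carbon gives a 3.5-fold lower number from compound 1 to compound 3 (0.55 log units; beyond the scatter) and lies beyond the scatter, so among these three compounds the clear difference goes with the aromatic group and not with the number of fluorine atoms. Nothing at hand accounts for either step.

Among these compounds, whether hydrogen in place of fluoro stays as silent with 4-bromophenyl in the molecule remains open, since the single pair for this change carries 4-methoxy-3-methylphenyl. Also open, from the compounds shown here alone, is how far this position tolerates a larger departure, such as a methyl group or a nitrile in place of trifluoromethyl, since both groups seen here are fluorinated methyl groups that read alike in this one pair.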